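This account rests on a few compounds, and the source may have more. Where it says the series, first, only, none or still open, it means among the compounds named here.

Compound 1 `CCSC(=S)SCC(=O)c1ccc(OC)cc1` gives 2510 nM in a functional assay on HeLa cells (Homo sapiens) for antiproliferative activity, read by resazurin assay (on this read-out higher numbers stand for weaker inhibition and lower numbers for stronger inhibition), and compound 2 `CCSC(=S)SCC(=O)c1ccc(OC)c(OC)c1` gives 5010 nM. Compound 1 thus has a single measured neighbour, and the two lie within the scatter of each other. Compound 3 `COc1ccc(C(=O)CSC(C)=O)cc1` keeps the core of compound 1 and differs by a group of 3 heavy atoms (2 carbon, 1 oxygen; no ring) in place of a group of 5 heavy atoms (3 carbon, 2 sulfur; no ring), on a sulfur. Going by the values given here, the only measured step, a 2.0-fold higher number from compound 1 to compound 2 (0.30 log units; within the scatter), is methoxy in place of hydrogen on an aromatic carbon, a different change, and no measured step touches the group on the sulfur. The expectation is therefore loose, with a modestly higher number expected in this assay, as an estimated 2.4-fold higher number from compound 1 to compound 3 (0.38 log units; beyond the scatter). Compound 3 is estimated at 6000 nM, with a range of 1500 nM to 25000 nM.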

Compound 3, half-maximal inhibitory concentration: 25100 nM
Estimate against measurement, compound 3: 4.2-fold (0.62 log units) below; measured number outside the range, above it.
By their numbers in this assay, from the lowest: compounds 1 and 2 (each within the scatter of the next); then compound 3.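

Acetyl in place of the group of 5 heavy atoms (3 carbon, 2 sulfur; no ring), on a sulfur, gives a 10-fold higher number from compound 1 to compound 3 (1.00 log units; beyond the scatter) in this assay. This is the only step shown that lies beyond the scatter, so the group on the sulfur is the one place in the series where a change registers clearly on this read-out. Nothing available explains this step.

Open, going by these compounds, is how a longer chain such as propionyl, or a benzoyl group, would read on the same sulfur. Also open, on these data alone, is whether acetyl on the core of compound 2 gives a step of similar size.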